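The source may hold more compounds than are shown below. What is called first, only, known or untested is meant among the compounds shown, and "the series" means these compounds.

Compound 1, `COc1ccc(-c2ssc(=O)c2-c2cc(OC)c(OC)c(OC)c2)cc1O`: 1910 nM
Compound 2, `COc1ccc(-c2ssc(=O)c2-c2cc(OC)c(OC)c(OC)c2)cc1N`: 147 nM
Compound 3, `COc1ccc(-c2ss/c(=N/O)c2-c2cc(OC)c(OC)c(OC)c2)cc1O`: 730 nM

All three were tested in a functional assay on HT-1080 cells (Homo sapiens) for antiproliferative activity, read by MTT assay, with a stated time of 72 h; a lower number here means a stronger inhibitor, a higher number a weaker inhibitor. Compound 1 carries a hydroxy on the methoxy-bearing ring and gives 1910 nM. Compound 2 differs from it in one place, (amino in place of hydroxy on an aromatic carbon), and the step is a 13-fold lower number from compound 1 to compound 2 (1.11 log units; beyond the scatter). Compound 3 shares the hydroxy and methoxy pattern of compound 1 but has a different core; the difference between the two cores is not broken down here. In this assay compound 3 gives 730 nM, a number that stands second highest of the three, nearer to compound 1 than to compound 2.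

Compound 4, `COc1ccc(-c2ss/c(=N/O)c2-c2cc(OC)c(OC)c(OC)c2)cc1N`, has not yet been measured. It relates to compound 3 as compound 2 relates to compound 1: amino in place of hydroxy on an aromatic carbon. The place is described in the same words for both pairs, so this is the same change, seen a second time on the core of compound 3. In this assay the expected step is a 9.1-fold lower number from compound 3 to compound 4 (0.96 log units; beyond the scatter), set beside the measured step of a 13-fold lower number from compound 1 to compound 2 (1.11 log units; beyond the scatter). The expectation rests on that single earlier step. Going by the values given here, only one such step is known, and the core of compound 3 differs from that of compound 1, so the step is expected to be somewhat smaller than a 13-fold lower number from compound 1 to compound 2 (1.11 log units; beyond the scatter). For compound 4 the estimated value is 80 nM, with a likely range from 25 nM to 250 nM.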

Compound 4, half-maximal inhibitory concentration: 9360 nM
Compound 4: middle estimate off by 120-fold (2.07 log units), on the low side; the whole stated range lies below it.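

In this assay the change from hydroxy to amino did not carry over from one core to the other: the step is a 13-fold higher number from compound 3 to compound 4 (1.11 log units; beyond the scatter), in the direction opposite to the one seen on the core of compound 1. The two steps differ by more than repeated measurements would explain: the same change on two cores in this assay, a 13-fold lower number (1.11 log units; beyond the scatter) from compound 1 to compound 2 and a 13-fold higher number (1.11 log units; beyond the scatter) from compound 3 to compound 4, 170-fold (2.22 log units) apart, beyond the scatter of two such steps. This shows that, across these two pairs, the effect of going from 3-hydroxy-4-methoxyphenyl to 3-amino-4-methoxyphenyl depends on the core that carries it, so a step measured on one core gave no guide to the other; with a single pair on each core, however, it does not show why the direction reverses or how the change would behave on any further core.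

The compounds shown leave open whether other groups in the same place, such as an acetamido group, a methylamino group or a fluorine, would also rank differently on the two cores. They also leave open whether the reversal is particular to these cells or would appear in other cell lines as well.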